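From One Number to an Unmeasured Hexyl Extension

The source may report more compounds than this note shows. Statements on the series, on what has been measured and on what is new or still open speak of the compounds shown alone.

Among the compounds with values here, in a functional assay on DU-145 cells (Homo sapiens) for cytotoxicity, read by MTT assay, with a stated time of 24 h (a higher number here means a weaker inhibitor, a lower number a stronger inhibitor), compound 1 `CCCCCCCCCCCC(=O)Nc1nnc(S[C@@H]2O[C@H](COC(C)=O)[C@H](OC(C)=O)[C@H](OC(C)=O)[C@H]2OC(C)=O)s1` gives 16900 nM and stands as the only compound with a number. Alongside it, compound 2 `CCCCCCCC(=O)Nc1nnc(S[C@@H]2O[C@H](CO)[C@H](O)[C@H](O)[C@H]2O)s1` gives "not active" (no number reported) as its entry, and compound 3 `CCCCCCCCCCCCCCCC(=O)Nc1nnc(S[C@@H]2O[C@H](CO)[C@H](O)[C@H](O)[C@H]2O)s1` gives "not active" (no number reported) as its entry, so neither offers a figure for comparison. Compound 4 `CCCCCCCCCCCCCCCCCC(=O)Nc1nnc(S[C@@H]2O[C@H](COC(C)=O)[C@H](OC(C)=O)[C@H](OC(C)=O)[C@H]2OC(C)=O)s1` has yet to be measured and is read here against compound 1. The difference between them is hexyl in place of hydrogen on a saturated chain carbon, ten or more bonds along the chain from a carbonyl carbon and nothing else in the structure changes.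

Within the data shown here, no pair of measured compounds shows what a change of this kind does, so any forecast stays loose. In this assay a modest step toward weaker inhibition is expected, although a step within the usual scatter would be no surprise. Among the measured compounds shown here, the only numerical anchor is compound 1 at 16900 nM in this series. Compound 4 could also return without a number, as compound 2 and compound 3 did. The expected change is a 1.5-fold higher number from compound 1 to compound 4 (0.17 log units; within the scatter) and it rests on that single value. For compound 4 the estimated value is 25000 nM with an expected range from 9000 nM to 70000 nM in this measurement.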

Compound 4, half-maximal inhibitory concentration: 31200 nM
Estimate against measurement, compound 4: 1.2-fold (0.10 log units) below; the measured number falls inside the stated range.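

In this assay, within the data shown here, hexyl in place of hydrogen on a saturated chain carbon, ten or more bonds along the chain from a carbonyl carbon, gives a 1.8-fold higher number from compound 1 to compound 4 (0.27 log units; within the scatter), the first step that can be read at this position. The earlier compounds shown here offered a single number and no step, whereas this pair shows that the change, with everything else in compound 1 left as it is, still returns a number rather than a "not active" entry, and that the two values cannot be told apart. No measurement shown here bears on what lies behind the size of this step.

Among these compounds, the "not active" entries of compound 2 and compound 3 give no step that can be read, and both compounds differ from compound 1 in more than one place, so the contribution of the chain cannot be separated from that of the rest of the structure. As far as these compounds go, what an amine, a carboxylic acid or a longer chain would do in place of the hexyl remains open.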